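The compounds below may be only part of what the source reports. "The series", "measured", "known", "first", "only" and "open" are said of these compounds alone.

Measured compounds:
compound 1 `CN(CCCCO)C(=O)OCCn1nnnc1[C@@H](COCc1ccccc1)NC(=O)C(C)(C)N` gives 3.8 nM in a functional assay on H4 cells with growth hormone secretagogue receptor type 1 (Homo sapiens) as the target, read by FLIPR; on this read-out higher numbers stand for an effect only at larger amounts of compound and lower numbers for an effect already at smaller amounts.
compound 2 `CC(C)(N)C(=O)N[C@H](COCc1ccccc1)c1nnnn1CCOC(=O)N1CC[C@@H](O)C1` gives 1 nM in this assay.
compound 3 `CC(C)(N)C(=O)N[C@H](COCc1ccccc1)c1nnnn1CCOC(=O)NC[C@H]1CCCO1` gives 9.5 nM in this assay.

Among these three, compound 3 carries the highest number, so it acts only at the largest amount of compound; the step of a 2.5-fold higher number from compound 1 to compound 3 (0.40 log units; beyond the scatter) and the step of a 9.5-fold higher number from compound 2 to compound 3 (0.98 log units; beyond the scatter) both lie beyond the scatter. The three compounds share one core and differ only in the group attached to the carbonyl carbon of the chain that hangs from the core.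

Compound 4 `CC(C)(N)C(=O)N[C@H](COCc1ccccc1)c1nnnn1CCOC(=O)NCCCn1ccnc1` has not yet been measured. It differs from compound 3 in that part alone: 2-(1H-imidazol-1-yl)ethyl in place of oxolan-2-yl on a saturated chain carbon bound to an amide-type nitrogen. Both steps already measured bear on this kind of change, since each also exchanged the group on that carbonyl carbon: a 2.5-fold higher number from compound 1 to compound 3 (0.40 log units; beyond the scatter) and a 9.5-fold higher number from compound 2 to compound 3 (0.98 log units; beyond the scatter), both of modest size. They show that this position tolerates quite different groups without the number moving by more than a modest amount, but give no direct hint about an imidazole ring.

For compound 4 a modest step in this assay downward from compound 3 is therefore expected, of size a 1.6-fold lower number from compound 3 to compound 4 (0.20 log units; within the scatter), and its value is estimated at 6 nM, within a range from 2 nM to 20 nM.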

Compound 4, half-maximal effective concentration: 45.3 nM
For compound 4 the middle estimate is 7.6-fold (0.88 log units) below the measured one; measured number above the stated range.
By their numbers in this assay, from the lowest: compound 2; then compound 1; then compound 3; then compound 4.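

In this assay the change to 3-(1H-imidazol-1-yl)propyl gives a 4.8-fold higher number from compound 3 to compound 4 (0.68 log units; beyond the scatter) and so shows that this position is less forgiving than the first three compounds suggested, with compound 4 now carrying the highest number of the four. The gap to the two compounds with a hydroxyl group is wider, at a 12-fold higher number from compound 1 to compound 4 (1.08 log units; beyond the scatter) and a 45-fold higher number from compound 2 to compound 4 (1.66 log units; beyond the scatter) and both large, whereas every step among the first three compounds was modest. Nothing shown here gives a reason for this rise.

The compounds shown leave open whether the rise goes with the imidazole ring itself or with the propyl chain that carries it, and a phenyl ring on the same propyl chain or an imidazole ring on a shorter ethyl chain would separate the two. As far as these compounds go, it also remains open how a simple amine or a carboxylic acid at the end of that chain would compare with the hydroxyl-bearing groups of compound 1 and compound 2.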